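Swapping Chloro for Acetyl on an Antiproliferative Series

A few compounds are considered here, and "the series" means these few. Any claim that something is new, unique, unknown or untested is made for them only; others in the source may bear on it.

Measured in a functional assay on HCT-116 cells (Homo sapiens) for antiproliferative activity, read by MTT assay, with a stated time of 72 h; on this read-out higher numbers stand for weaker inhibition and lower numbers for stronger inhibition:
- compound 1 `Nc1nc(N)c2cc(CSC(=S)N3CCN(C4CCCCC4)CC3)ccc2n1`: 8400 nM
- compound 2 `Nc1nc(N)c2cc(CSC(=S)N3CCN(c4ccc(Cl)cc4)CC3)ccc2n1`: 7380 nM

With only these two numbers available, compound 2 at 7380 nM stands level with compound 1, since the gap between them lies within the scatter. Compound 3 `CC(=O)c1ccc(N2CCN(C(=S)SCc3ccc4nc(N)nc(N)c4c3)CC2)cc1` has acetyl in place of chloro on an aromatic carbon, para to a large group: acetyl in place of chloro on an aromatic carbon. Within the data shown here, one measured step bears on this, and only indirectly. Putting 4-chlorophenyl in place of cyclohexyl on an amine nitrogen in a ring gave a 1.1-fold lower number from compound 1 to compound 2 (0.06 log units; within the scatter). Among the measured compounds shown here, no measured step changes the group at the site that differs in compound 3, so this evidence is thin. The small size of that one step gives no reason to expect a change beyond the scatter in this assay. The estimated change is a 1.1-fold lower number from compound 2 to compound 3 (0.02 log units; within the scatter). For compound 3 the expected value is 7000 nM, with an estimated range of 2800 nM to 16000 nM.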

Compound 3, half-maximal inhibitory concentration: 8260 nM
Estimate against measurement, compound 3: 1.2-fold (0.07 log units) below; the measured number falls inside the stated range.
By their numbers in this assay, from the lowest: compounds 2, 3 and 1 (each within the scatter of the next).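

Among these compounds, this is the first direct change at this place on the aromatic ring, and in this assay acetyl in place of chloro gives a 1.1-fold higher number from compound 2 to compound 3 (0.05 log units; within the scatter) and so stays within the scatter. Acetyl brings a double bond outside the ring and a hydrogen-bond acceptor that chloro lacks, yet the number does not move beyond the scatter, and 4-acetylphenyl in place of cyclohexyl on the ring amine nitrogen likewise gives a 1.0-fold lower number from compound 1 to compound 3 (0.01 log units; within the scatter) as a step within the scatter. Nothing measured here accounts for this lack of separation.

As far as these compounds go, whether an amine, a carboxylic acid or a longer chain at this same place would give a step beyond the scatter remains open. From the compounds shown here alone, the three compounds also share one core, so what a change to that core would do is unknown.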